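This account rests on a few compounds, and the source may have more. Where it says the series, first, only, none or still open, it means among the compounds named here.

Working notes on the series. Compound 1 `COc1cc2c(Oc3ccc(NC(=O)c4nn(-c5ccccc5F)c(=O)c5ccccc45)cc3F)ccnc2cc1OCCCN1CCN(C)CC1` gives 210 nM in a functional assay on MKN-45 cells (Homo sapiens) for cytotoxicity, read by MTT assay, with a stated time of 72 h; a lower number here means a stronger inhibitor, a higher number a weaker inhibitor. Compound 2 `COc1cc2c(Oc3ccc(NC(=O)c4nn(-c5ccccc5F)c(=O)c5ccccc45)cc3F)ccnc2cc1OCCCN1CCCCC1` gives 350 nM in this assay. Among the measured compounds shown here, the one measured step, a 1.7-fold higher number from compound 1 to compound 2 (0.22 log units; within the scatter), stays within the scatter. Compound 3 `COc1cc2c(Oc3ccc(NC(=O)c4nn(-c5cccc(F)c5)c(=O)c5ccccc45)cc3F)ccnc2cc1OCCCN1CCC(C)CC1` gives 220 nM in this assay, the second highest of the three numbers, lying between those of compound 1 and compound 2 and within the scatter of both. Compound 4 `COc1cc2c(Oc3ccc(NC(=O)c4nn(-c5ccccc5F)c(=O)c5ccccc45)cc3F)ccnc2cc1OCCCN1CCC(C)CC1` differs from compound 3 by 2-fluorophenyl in place of 3-fluorophenyl on an aromatic nitrogen. For the measured compounds named here, no measured pair exchanges one fluorophenyl for the other on that aromatic nitrogen, so no measured step bears directly on this change; the only step available concerns another part of the shared core. The expected step of no change at the digits printed from compound 3 to compound 4 (within the scatter) is therefore none beyond the scatter. Compound 4 is estimated at 220 nM, with a range from 110 nM to 440 nM.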

Compound 4, half-maximal inhibitory concentration: 260 nM
Beside the measured number, compound 4's estimate is 1.2-fold (0.07 log units) below it; low and high end bracket the measured number.
By their numbers in this assay, from the lowest: compounds 1, 3, 4 and 2 (each within the scatter of the next).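

In this assay, the exchange of 3-fluorophenyl for 2-fluorophenyl on the aromatic nitrogen can now be read directly (a 1.2-fold higher number from compound 3 to compound 4 (0.07 log units; within the scatter)) and stays within the scatter. With 2-fluorophenyl held fixed, the methyl on the saturated ring carbon (a 1.3-fold lower number from compound 2 to compound 4 (0.13 log units; within the scatter)) and 4-methylpiperidin-1-yl in place of 4-methylpiperazin-1-yl (a 1.2-fold higher number from compound 1 to compound 4 (0.09 log units; within the scatter)) also stay within the scatter. No measurement at hand accounts for these steps. Going by these compounds, whether a phenyl without fluorine on that aromatic nitrogen, or a morpholin-4-yl at the chain end, would step beyond the scatter remains open.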